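The source may report more compounds than this note shows. Statements on the series, on what has been measured and on what is new or still open speak of the compounds shown alone.

Compound 2 `C[Se]/C(=N\C(=O)c1cnc2ccccc2c1)NC(=O)c1cnc2ccccc2c1` was tested in a functional assay on HepG2 cells (Homo sapiens) for cytotoxicity, read by MTT assay, with a stated time of 72 h (a lower number here means that less compound is tolerated, a higher number that more compound is tolerated), where compound 2 gives 87800 nM. Compound 1 `C[Se]/C(=N\C(=O)c1cc2ccccc2s1)NC(=O)c1cc2ccccc2s1` gives 73300 nM in this assay. Compound 2 sits at the top of these two numbers, yet its gap to compound 1 lies within the scatter, so the two cannot be told apart. Compound 3 `CS/C(=N\C(=O)c1cnc2ccccc2c1)NC(=O)c1cnc2ccccc2c1` differs from compound 2 in one place: a group of 2 heavy atoms (1 carbon, 1 sulfur; no ring) in place of a group of 2 heavy atoms (1 carbon, 1 selenium; no ring), on a carbon with a double bond to nitrogen. Within the data shown here, no measured pair shows this exchange, so its direction is open; a step no larger than the scatter is expected, a 1.0-fold lower number from compound 2 to compound 3 (0.01 log units; within the scatter). Compound 3 is expected to give 85000 nM, between 40000 nM and 180000 nM.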

Compound 3, concentration lethal to 50% of the cells: > 100000 nM
Compound 3: no number, only a limit (the forecaster's own chance of this, stated with the estimate: 10%); middle value at least 1.1-fold (0.07 log units) from the limit.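

In this assay, compound 3 carries a limit and not a number: the limit of > 100000 nM in this assay, at which 1 of the 3 values shown sits. Among these compounds, exchanging the selenium-bearing group for methylsulfanyl on this carbon, an exchange the earlier compounds did not show, gives an at least 1.1-fold higher number from compound 2 to compound 3 (0.05 log units; that floor lies within the scatter). On these data alone, the change therefore has a direction only as a floor, and that floor does not separate the two compounds, while the true size of the step stays unknown.

As far as these compounds go, whether the same exchange behaves alike on the core of compound 1 stays open. So does the outcome of a methoxy group or a longer chain such as ethylsulfanyl on this carbon.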